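The source may hold more compounds than are shown below. What is called first, only, known or untested is meant among the compounds shown, and "the series" means these compounds.

In a functional assay on PC-3 cells (Homo sapiens) for cytotoxicity, read by MTT assay, with a stated time of 48 h (on this read-out higher numbers stand for weaker inhibition and lower numbers for stronger inhibition), compound 1 `COc1ccc(-c2c[nH]c(=O)n2-c2cc(OC)c(OC)c(OC)c2)cc1[N+](=O)[O-]` gives > 50000 nM, which is a limit of the assay and not a number. Compound 2 `COc1cc(NC(=O)n2cc(-c3ccc(O)cc3)n(-c3cc(OC)c(OC)c(OC)c3)c2=O)cc(OC)c1OC` gives 3000 nM, and compound 3 `COc1ccc(-c2cn(C(=O)Nc3cc(OC)c(OC)c(OC)c3)c(=O)n2-c2cc(OC)c(OC)c(OC)c2)cc1` gives 49700 nM. Among the measured compounds shown here, compound 3 therefore stands highest of the two actual numbers, with compound 2 as its only numerical neighbour.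

Next in line is compound 4 `COc1ccc(-c2cn(C(=O)Nc3cc(OC)c(OC)c(OC)c3)c(=O)n2-c2cc(OC)c(OC)c(OC)c2)cc1OC`, with this difference from compound 3: methoxy in place of hydrogen on an aromatic carbon. This is methoxy in place of hydrogen on an aromatic carbon, taking 4-methoxyphenyl to 3,4-dimethoxyphenyl.

For the measured compounds named here, only one measured step bears on this change: a 17-fold higher number from compound 2 to compound 3 (1.22 log units; beyond the scatter), with methyl in place of hydrogen on an oxygen on an aromatic ring. That large step removed a hydrogen on oxygen. Compound 4 keeps the methoxy of compound 3 and adds a second one on carbon, so the size of the earlier step does not carry over. Going by the values given here, no measured step shows this change directly, so no shift beyond the scatter is expected in this assay. The expected step is a 1.4-fold lower number from compound 3 to compound 4 (0.15 log units; within the scatter). For compound 4 the estimated value is 35000 nM, with an expected range from 10000 nM to 60000 nM.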

Compound 4, half-maximal inhibitory concentration: > 50000 nM
Compound 4: only a limit was reported; the forecaster's own chance of this, stated with the estimate: 35%; middle value at least 1.4-fold (0.15 log units) from the limit.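

In this assay compound 4 gives > 50000 nM, which is a limit of the assay and not a number. Among the compounds shown here, this leaves a number no lower from compound 3 to compound 4 (the limit leaves the size open), so adding methoxy on this aromatic carbon, ortho to a methoxy group, has no measured size, and the top of the assay range now holds a further member of the series: the limit of > 50000 nM in this assay, at which 2 of the 4 values shown sit. The readable result is an at least 16-fold higher number from compound 2 to compound 4 (1.22 log units; beyond the scatter), which replaces the whole 4-hydroxyphenyl with 3,4-dimethoxyphenyl and so does not separate the loss of the hydroxyl from the added methoxy, while a 17-fold higher number from compound 2 to compound 3 (1.22 log units; beyond the scatter) remains the only step that isolates the change at the hydroxyl.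

Still open, going by these compounds, is whether any substituent added to the 4-hydroxyphenyl of the more active compound 2 would be tolerated, since the new methoxy has only been placed on a ring already bearing a methoxy group and at the assay's limit. How an amine or a carboxylic acid in place of that hydroxyl would read in this assay also remains unresolved.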